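A few compounds are considered here, and "the series" means these few. Any claim that something is new, unique, unknown or untested is made for them only; others in the source may bear on it.

The measured compounds:

Compound 1, `Cc1ccccc1OS(=O)(=O)c1ccc(N2CCN(C)C2=O)cc1`, gives 5600 nM.
Compound 2, `CN1CCN(c2ccc(S(=O)(=O)Oc3cccc(Br)c3)cc2)C1=O`, gives 1500 nM.
Compound 3, `COc1ccc(OS(=O)(=O)c2ccc(N3CCN(C)C3=O)cc2)cc1`, gives 95000 nM.

All three numbers come from a functional assay on MCF7 cells (Homo sapiens) for antiproliferative activity, read by sulforhodamine B assay, with a stated time of 48 h; a lower number here means a stronger inhibitor, a higher number a weaker inhibitor. Among them compound 1 stands second highest: its nearest neighbour is compound 2, reached by a 3.7-fold lower number from compound 1 to compound 2 (0.57 log units; beyond the scatter), and its furthest is compound 3, reached by a 17-fold higher number from compound 1 to compound 3 (1.23 log units; beyond the scatter). The remaining pair shows a 63-fold higher number from compound 2 to compound 3 (1.80 log units; beyond the scatter).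

The unmeasured compound 4, `CN1CCN(c2ccc(S(=O)(=O)Oc3ccc(Cl)cc3)cc2)C1=O`, differs from compound 1 in one place: 4-chlorophenyl in place of 2-methylphenyl on an oxygen. Among the measured compounds shown here, two measured steps bear on this change, since both also swap the group on that oxygen of compound 1. Trading 2-methylphenyl for a halogen-bearing ring gave a 3.7-fold lower number from compound 1 to compound 2 (0.57 log units; beyond the scatter), a modest drop in the number, while trading it for 4-methoxyphenyl gave a 17-fold higher number from compound 1 to compound 3 (1.23 log units; beyond the scatter), a large rise. The incoming 4-chlorophenyl shares a halogen with the ring of compound 2 but the substitution pattern of the ring of compound 3, so the two precedents pull in opposite directions. On balance a step of a 1.4-fold lower number from compound 1 to compound 4 (0.15 log units; within the scatter) is expected in this assay , with the middle of the range near compound 1 and wide uncertainty toward either neighbour. Compound 4 is therefore estimated at 4000 nM, within 1000 nM to 20000 nM.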

Compound 4, half-maximal inhibitory concentration: > 100000 nM
Compound 4: only a limit was reported; the forecaster's own chance of this, stated with the estimate: 5%; middle value at least 25-fold (1.39 log units) away from the limit.
By their numbers in this assay, from the lowest: compound 2; then compound 1; then compound 3. At a limit, above all of these: compound 4.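

In this assay compound 4 is reported only as a limit, > 100000 nM. On this oxygen, whose other neighbour is the sulfonyl sulfur, a halogen on the ring does not by itself bring the lower number seen with compound 2: 4-chlorophenyl in place of 2-methylphenyl gives an at least 17-fold higher number from compound 1 to compound 4 (1.25 log units; beyond the scatter), 4-chlorophenyl in place of 3-bromophenyl gives an at least 66-fold higher number from compound 2 to compound 4 (1.82 log units; beyond the scatter), and chloro in place of methoxy on an aromatic carbon gives an at least 1.0-fold higher number from compound 3 to compound 4 (0.02 log units; that floor lies within the scatter). Among these four compounds, the two rings named with a 4, 4-methoxyphenyl and 4-chlorophenyl, now both stand at the high end, while 2-methylphenyl and 3-bromophenyl give the lower numbers, although the floor of the step for chloro in place of methoxy lies within the scatter and the high end of this comparison rests on a limit of the assay: the limit of > 100000 nM in this assay, at which 1 of the 4 values shown sits.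

The compounds shown leave open whether it is the chlorine or its place on the ring that matters, since a 3-chlorophenyl or 2-chlorophenyl group could separate the two. They also leave open how a 4-methylphenyl group, or a ring carrying an amine or a carboxylic acid, would behave on this oxygen.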